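Halogenated benzylidene series: cytotoxicity notes toward compound 3

The source may hold more compounds than are shown below. What is called first, only, known or untested is meant among the compounds shown, and "the series" means these compounds.

Three compounds share one core, differing only in the aryl group on the exocyclic double bond. Compound 1 `CN(C)c1ccc(/C=C2\C(=O)N(c3c(Cl)cccc3Cl)c3ccccc32)cc1` stands at "not determined" (no result reported) in a functional assay on MOLT-4 cells (Homo sapiens) for cytotoxicity, read by MTT assay, with a stated time of 72 h (on this read-out lower numbers stand for an effect already at smaller amounts and higher numbers for an effect only at larger amounts of compound), that is, no result is reported for it. Compound 2 `O=C1/C(=C\c2cccc(Br)c2)c2ccccc2N1c1c(Cl)cccc1Cl` gives 7 ug/mL in this assay and is thus the only number shown there, with one further entry lacking a single value; no ranking against other compounds is possible on this basis.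

Compound 3 `O=C1/C(=C\c2ccccc2Cl)c2ccccc2N1c1c(Cl)cccc1Cl` is unmeasured. It differs from compound 2 by 2-chlorophenyl in place of 3-bromophenyl on a double-bonded chain carbon bound to a double-bonded ring carbon. Going by the values given here, no step between two measured compounds exists in this set, so the effect of swapping one halogenated phenyl for another cannot be read from data; only the value of compound 2 anchors the expectation. With both groups counted as one six-membered aromatic ring bearing a single halogen and no donors or acceptors, the expected step from compound 2 to compound 3 in this assay is a 1.1-fold higher number from compound 2 to compound 3 (0.06 log units; within the scatter), which is not expected to exceed the usual scatter in either direction. Compound 3 is therefore estimated at 8 ug/mL in this assay, with a range from 3 ug/mL to 20 ug/mL.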

Compound 3, concentration for half-maximal effect: 7 ug/mL
Beside the measured number, compound 3's estimate is 1.1-fold (0.06 log units) above it, within the range that was stated.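

In this assay, going by these compounds alone, the first step that can be read is no change at the digits printed from compound 2 to compound 3 (within the scatter), for 2-chlorophenyl in place of 3-bromophenyl on a double-bonded chain carbon bound to a double-bonded ring carbon. At this position, then, one halogen-bearing phenyl can replace another with no shift in the read-out beyond the scatter, although the two groups differ both in the halogen and in where it sits, and this single step cannot separate those two differences. Nothing available on this series accounts for the unchanged read-out.

Steps involving compound 1 cannot be read, so the dimethylamino-bearing aryl group remains without a comparison in this series. Also open, from the compounds shown here alone, is whether the read-out would hold with a phenyl carrying a carboxylic acid or a primary amine in the same place, or with a longer alkyl chain in place of the aromatic ring.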